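The compounds below may be only part of what the source reports. "The series", "measured", "known", "first", "only" and "open" are said of these compounds alone.

Measured compounds, all in a functional assay on HEp-2 cells (Homo sapiens) for antiproliferative activity, read by MTT assay, with a stated time of 72 h; on this read-out higher numbers stand for weaker inhibition and lower numbers for stronger inhibition:
Compound 1, `O=c1cc(CSC(=S)N2CCCCC2)oc2cc(Cl)ccc12`, gives 1600 nM.
Compound 2, `O=c1cc(CSC(=S)N2CCCC2)oc2cc(Cl)ccc12`, gives only a limit of the assay, > 40000 nM.
Compound 3, `COc1ccc2occ(CSC(=S)N3CCCC3)c(=O)c2c1`, gives 3100 nM.

Compound 1 and compound 2 share one core and differ in a single place: piperidin-1-yl in place of pyrrolidin-1-yl on a thiocarbonyl carbon. That change gives an at least 25-fold lower number from compound 2 to compound 1 (1.39 log units; beyond the scatter). The true size of this step is not known, because compound 2 sits at the limit of > 40000 nM in this assay, at which 1 of the 3 values shown sits. Compound 3 has a different core; the difference between the two cores is not broken down here. Compound 3 and compound 1 give numbers within the usual scatter of each other.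

Compound 4, `COc1ccc2occ(CSC(=S)N3CCCCC3)c(=O)c2c1`, is not yet measured. It differs from compound 3 by piperidin-1-yl in place of pyrrolidin-1-yl on a thiocarbonyl carbon, the same change as between compound 2 and compound 1. Whether the step carries over to the core of compound 3 is not known from these three compounds.

The step from compound 3 to compound 4 is expected to be a 3.9-fold lower number from compound 3 to compound 4 (0.59 log units; beyond the scatter), smaller than an at least 25-fold lower number from compound 2 to compound 1 (1.39 log units; beyond the scatter) since that step was measured on a different core and is only a bound. In this assay compound 4 is expected to give about 800 nM. The estimate for compound 4 is expected to fall between 200 nM and 3000 nM.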

Compound 4, half-maximal inhibitory concentration: 4300 nM
The estimate for compound 4 lay 5.4-fold (0.73 log units) below the measured number; the measured number lies above the stated range.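

In this assay, putting piperidin-1-yl in place of pyrrolidin-1-yl on the thiocarbonyl carbon gives a 1.4-fold higher number from compound 3 to compound 4 (0.14 log units; within the scatter), so on the core of compound 3 this change has no effect that can be told apart from the scatter. The large step seen on the core of compound 1 therefore does not carry over to the core of compound 3, and the two steps clearly differ: the same change on two cores in this assay, an at least 25-fold lower number (1.39 log units; beyond the scatter) from compound 2 to compound 1 and a 1.4-fold higher number (0.14 log units; within the scatter) from compound 3 to compound 4, at least 34-fold (1.54 log units) apart, beyond the scatter of two such steps. This does not show why the two cores respond differently, and it does not give the true size of the earlier step, since compound 2 gives only a limit of the assay: the limit of > 40000 nM in this assay, at which 1 of the 4 values shown sits.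

The compounds shown leave open which part of the difference between the two cores decides the outcome. As far as these compounds go, it also remains open how other amines on the thiocarbonyl carbon, such as morpholin-4-yl or diethylamino, would behave on either core.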